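Swapping hydroxy for amino: what happens to distribution?

A few compounds are considered here, and "the series" means these few. Any claim that something is new, unique, unknown or untested is made for them only; others in the source may bear on it.

Compound 1, `N#Cc1ccc(O[C@H]2CN(S(=O)(=O)c3ccc(Cl)cc3Cl)C[C@@]2(O)CN)cc1F`, gives 210 L/kg in an ADME assay on the whole organism (Rattus norvegicus, strain Sprague-Dawley) for pharmacokinetics, read by LC-MS, with a stated time of 30 min; a higher number here means that more of the compound sits outside the plasma, a lower number that more of the compound stays in the plasma.
Compound 2, `N#Cc1ccc(O[C@H]2CN(S(=O)(=O)c3ccc(Cl)cn3)C[C@@]2(O)CO)cc1F`, gives 12 L/kg in this assay.

Among the measured compounds shown here, of these two numbers, compound 2 has the lower one, and the only neighbour, compound 1, stands well beyond the usual scatter above it. The two compounds differ in more than one place, so nothing can be said about what any single change did between them.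

Compound 3, `N#Cc1ccc(O[C@H]2CN(S(=O)(=O)c3ccc(Cl)cn3)C[C@@]2(O)CN)cc1F`, is not yet measured in this assay. It differs from compound 2 in one place: amino in place of hydroxy on a saturated chain carbon bound to a saturated ring carbon. Compound 1 carries the same aminomethyl group, but on a different sulfonyl ring, so it is only a loose guide.

The expectation for compound 3 is a step upward from compound 2 that is beyond the scatter, a 5.0-fold higher number from compound 2 to compound 3 (0.70 log units; beyond the scatter), because in this assay compound 1 gives 210 L/kg. Compound 3 is estimated at 60 L/kg, with a range from 20 L/kg to 180 L/kg.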

Compound 3, volume of distribution at steady state: 47 L/kg
The estimate for compound 3 lay 1.3-fold (0.11 log units) above the measured number, within the range that was stated.
By their numbers in this assay, from the lowest: compound 2; then compound 3; then compound 1.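

Amino in place of hydroxy, with the sulfonyl ring unchanged, gives a 3.9-fold higher number from compound 2 to compound 3 (0.59 log units; beyond the scatter) in this assay, so this single change on a saturated chain carbon bound to a saturated ring carbon moves the number beyond the scatter by itself. With the aminomethyl group held constant, 5-chloropyridin-2-yl in place of 2,4-dichlorophenyl on a sulfonyl sulfur gives a 4.5-fold lower number from compound 1 to compound 3 (0.65 log units; beyond the scatter) as a second step beyond the scatter, so the sulfonyl ring also counts. Nothing measured here explains why either change moves the distribution.

As far as these compounds go, it remains open how a longer chain such as aminoethyl, or a substituted amine such as dimethylaminomethyl, would behave at this place. From the compounds shown here alone, the size of the hydroxymethyl to aminomethyl step with 2,4-dichlorophenyl on the sulfonyl sulfur also remains open.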